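Isopropyl ester expected to hold at the stability limit

The compounds below may be only part of what the source reports. "The series", "measured", "known", "first", "only" and "open" are said of these compounds alone.

Compound 1 `CCC(CC)C(=O)OCOC(=O)C1=C(S[C@@H]2CN[C@H](C(=O)Nc3cccc(C(=O)O)c3)C2)[C@H](C)[C@@H]2[C@@H]([C@@H](C)O)C(=O)N12` gives > 95% in an ADME assay for metabolic stability, read by LC-MS, with a stated time of 3 h, at pH 6.5, tested at 50 uM; a higher number here means that more of the compound is left, a lower number that less of the compound is left.
Compound 2 `CC(C)OC(=O)C1=C(S[C@@H]2CN[C@H](C(=O)Nc3cccc(C(=O)OC(C)C)c3)C2)[C@H](C)[C@@H]2[C@@H]([C@@H](C)O)C(=O)N12` gives > 95% in this assay.
Compound 3 `COC(=O)OCOC(=O)C1=C(S[C@@H]2CN[C@H](C(=O)Nc3cccc(C(=O)O)c3)C2)[C@H](C)[C@@H]2[C@@H]([C@@H](C)O)C(=O)N12` gives > 95% in this assay.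

Each of these three values is a limit of this assay rather than a number. Compound 3 therefore stands at the limit of > 95% in this assay, at which 3 of the 3 values shown sit. Among the compounds with values here, the only one-place step among the measured compounds, a step that the two limits leave unreadable from compound 1 to compound 3, runs from one limit to another, so its size cannot be read.

Compound 4 `CC(C)OC(=O)C1=C(S[C@@H]2CN[C@H](C(=O)Nc3cccc(C(=O)O)c3)C2)[C@H](C)[C@@H]2[C@@H]([C@@H](C)O)C(=O)N12` has not been measured in this assay. It differs from compound 3 by isopropyl in place of ((methoxycarbonyl)oxy)methyl on an oxygen next to a carbonyl group. Within the data shown here, no measured step covers this exact change. Compound 2, which carries isopropyl on both of its esters, sits at a limit in this assay; its value was given above. With compound 2 and compound 3 both at the limit, the step from compound 3 to compound 4 is expected to show no change beyond the scatter, which is what a step that the limit leaves unreadable from compound 3 to compound 4 expresses. Compound 4 is accordingly estimated at 97% in this assay, within a range from 86% to 100%, and is most likely to be reported again as a limit.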

Compound 4, percent of the compound remaining: > 95%
Compound 4: a limit, no number (the forecaster's own chance of this, stated with the estimate: 80%); the middle value does not contradict the limit.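

The result for compound 4 is a limit in this assay, as are those for compound 1, compound 2 and compound 3, so none of the new steps joining compound 4 to those three can be read: the limit of > 95% in this assay, at which 4 of the 4 values shown sit.

The compounds shown leave open whether these four differ at all in this assay, and whether any ester would fall short of that limit.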